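Replacing ethynyl with 1-fluoroethenyl in compound 2

The source may hold more compounds than are shown below. What is called first, only, known or untested is meant among the compounds shown, and "the series" means these compounds.

In an ADME assay on Caco-2 cells (Homo sapiens) for permeability (a lower number here means that the compound crosses the layer more slowly, a higher number that the compound crosses the layer faster), compound 1 `C#CCN(CC=C)C(=O)[C@@]1(c2ccsc2)C[C@H]1CN` gives 96 nm/s and compound 2 `C#CCN(CCOC)C(=O)[C@@]1(c2ccsc2)C[C@H]1CN` gives 32 nm/s, so compound 2 holds the lower of the two numbers. Compound 3 `C=C(F)CN(CCOC)C(=O)[C@@]1(c2ccsc2)C[C@H]1CN` differs from compound 2 in one place: 1-fluoroethenyl in place of ethynyl on a saturated chain carbon bound to an amide-type nitrogen. This is 1-fluoroethenyl in place of ethynyl on a saturated chain carbon bound to an amide-type nitrogen. Within the data shown here, only one measured step is available as a guide, a 3.0-fold lower number from compound 1 to compound 2 (0.48 log units; beyond the scatter), and it is modest. That step swaps vinyl for methoxymethyl and leaves the ethynyl untouched, so it gives only a rough size for a change of this kind, and no direction. Among the measured compounds shown here, no measured step covers the ethynyl swap itself. The expected change, a 1.2-fold higher number from compound 2 to compound 3 (0.07 log units; within the scatter), is therefore none beyond the scatter. The estimate for compound 3 is 38 nm/s, with an expected range of 16 nm/s to 90 nm/s.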

Compound 3, apparent permeability: 34 nm/s
Compound 3: the middle estimate sits 1.1-fold (0.05 log units) above what was measured; low and high end bracket the measured number.
By their numbers in this assay, from the lowest: compounds 2 and 3 (each within the scatter of the next); then compound 1.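

In this assay, among these compounds, 1-fluoroethenyl in place of ethynyl on a saturated chain carbon bound to an amide-type nitrogen gives a 1.1-fold higher number from compound 2 to compound 3 (0.03 log units; within the scatter), the only reading of a change to this group, as the earlier pair kept the ethynyl fixed. On the background of compound 2, then, propargyl and 2-fluoroprop-2-en-1-yl are not told apart by this read-out, even though the entering group has one more heavy atom and a double bond where the leaving group has a triple bond. Nothing in hand offers an explanation for this result.

From the compounds shown here alone, whether the swap reads the same on the vinyl-bearing background of compound 1 remains open. Also open, going by these compounds, is how a nitrile, a cyclopropyl group or a longer chain would read in place of the ethynyl.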